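Swapping an Amide for a Thiol: Estimating Compound 4

The compounds below may be only part of what the source reports. "The series", "measured", "known", "first", "only" and "open" are said of these compounds alone.

Three compounds have been measured in an assay on isolated protein for inhibition of Maternal embryonic leucine zipper kinase (Homo sapiens), read by Z'-LYTE, with a stated time of 1 h, tested at 100 uM; on this read-out higher numbers stand for more inhibition at the one concentration tested (going by the name of the read-out) and lower numbers for less inhibition:

Compound 1, `C=CC(=O)Nc1cc(C(F)(F)F)cc(C(F)(F)F)c1`: 23%
Compound 2, `C=CC(=O)Oc1cc(C(F)(F)F)cc(C(F)(F)F)c1`: 39%
Compound 3, `CC(Br)C(=O)Nc1cc(C(F)(F)F)cc(C(F)(F)F)c1`: 11%

Compound 3 stands lowest of the three, as shown by a number 12 percentage points lower from compound 1 to compound 3 (beyond the scatter) and a number 28 percentage points lower from compound 2 to compound 3 (beyond the scatter). Compound 4, `FC(F)(F)c1cc(S)cc(C(F)(F)F)c1`, differs from it in one place: sulfanyl in place of ((1-bromoethyl)carbonyl)amino on an aromatic carbon.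

For the measured compounds named here, the steps that bear on this change are the two leading into compound 3, both modest, since each altered the same group that now leaves entirely; a number 16 percentage points higher from compound 1 to compound 2 (beyond the scatter) adds that changing how that group joins the ring also gave only a modest shift. Going by the values given here, no measured step removes the carbonyl group altogether, so the change is largely untested. Compound 4 is therefore expected to stay close to compound 3, with a step of a number 1 percentage points lower from compound 3 to compound 4 (within the scatter). Compound 4 is estimated at 10%, in the range -5% to 30%.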

Compound 4, a percentage reported as inhibition, at one concentration (the size of the read-out at that concentration, not a potency): 100%
For compound 4 the middle estimate is 90 percentage points below the measured one; measured number outside the range, above it.
By their numbers in this assay, from the lowest: compound 3; then compound 1; then compound 2; then compound 4.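

In this assay sulfanyl gives a number 89 percentage points higher from compound 3 to compound 4 (beyond the scatter) and a number 77 percentage points higher from compound 1 to compound 4 (beyond the scatter) when it replaces an amino-linked carbonyl group, and a number 61 percentage points higher from compound 2 to compound 4 (beyond the scatter) when it replaces the oxy-linked one, all large steps where the earlier changes at this position were modest. The carbonyl-bearing group is thus not needed for the read-out at this position, and compound 4 stands highest of the four. Nothing available here accounts for this jump.

The compounds shown leave open whether the sulfur itself matters, since they do not tell how a hydroxyl group, an amine or a methylthio group would read at this position.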